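A few compounds are considered here, and "the series" means these few. Any claim that something is new, unique, unknown or untested is made for them only; others in the source may bear on it.

The series centres on inhibition of Rho-associated protein kinase 1, followed in an assay on isolated protein for inhibition of Rho-associated protein kinase 1 (Homo sapiens); on this read-out higher numbers stand for weaker inhibition and lower numbers for stronger inhibition. Of the compounds shown here, three have been measured. Compound 1 `COc1cccc(CN(C)C(=O)c2cc3ccc(-c4cn[nH]c4)cc3[nH]2)c1` carries a methyl on its amide nitrogen and gives 37 nM in this assay. Compound 3 `COc1cccc(CN(C(=O)c2c[nH]c3nc(-c4cn[nH]c4)ccc23)C2CC2)c1` carries a cyclopropyl on the amide nitrogen and gives 30 nM. Compound 2 `COc1cccc(CNC(=O)c2c[nH]c3cc(-c4cn[nH]c4)ccc23)c1` has an unsubstituted amide nitrogen, and for compound 2 this assay reports only a limit, < 1 nM; this is the floor of the read-out, not a number, and (the limit of < 1 nM in this assay, at which 1 of the 3 values shown sits). Compound 2 therefore stands at the strong end of what the assay can resolve, while compounds 1 and 3 sit well within the measurable range.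

Compound 4 `COc1cccc(CN(C)C(=O)c2c[nH]c3cc(-c4cn[nH]c4)ccc23)c1` has not yet been measured. It differs from compound 2 in one place: methyl in place of hydrogen on an amide-type nitrogen. Among the measured compounds shown here, no single-point step between measured compounds covers this change, so the expected direction rests on the structures alone. Because compound 1 gives 37 nM and compound 3 gives 30 nM, both with a substituted amide nitrogen, the expectation is that compound 4 loses potency beyond the scatter, by a step of an at least 10-fold higher number from compound 2 to compound 4 (1.00 log units; beyond the scatter). Compound 4 is thus estimated at 10 nM, with a likely range from 1.5 nM to 70 nM.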

Compound 4, half-maximal inhibitory concentration: 19 nM
For compound 4 the middle estimate is 1.9-fold (0.28 log units) below the measured one; low and high end bracket the measured number.
By their numbers in this assay, from the lowest: compounds 4, 3 and 1 (each within the scatter of the next). At a limit, below all of these: compound 2.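

Among the compounds shown here, the earlier compounds with a substituted amide nitrogen each differed from compound 2 in more than one place, so this pair is the first to isolate the change: in this assay, methyl in place of hydrogen on an amide-type nitrogen gives an at least 19-fold higher number from compound 2 to compound 4 (1.27 log units; beyond the scatter), a loss of potency beyond the scatter from a single added carbon. For compound 2 the read-out gives only a limit, < 1 nM, and not a number. The step therefore fixes the direction and a minimum size for this change, but its full size cannot be read, because the parent compound lies at the floor of the read-out: the limit of < 1 nM in this assay, at which 1 of the 4 values shown sits.

The compounds shown leave open whether the loss follows from any replacement of the amide hydrogen or depends on the group that enters, since no ethyl, longer chain or amine-bearing chain stands on this nitrogen of the shared core. They also leave open how the same change would read on the cores of compound 1 and compound 3, where no version with the amide hydrogen appears.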